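The compounds below may be only part of what the source reports. "The series", "measured", "known", "first", "only" and "open" are said of these compounds alone.

Compound 2, `CC(=O)NC1CCN(c2ncnc3[nH]cc(-c4cccc(Cl)c4)c23)CC1`, gives 139 nM in an assay on HEK293T cells for displacement of a labelled ligand from serine/threonine-protein kinase 3 (Homo sapiens), read by NanoBRET, with a stated time of 2 h (a higher number here means a weaker inhibitor, a lower number a stronger inhibitor), the lowest of the two numbers recorded. Compound 1, `OCCCNc1ncnc2[nH]cc(-c3cccc(Cl)c3)c12`, gives 668 nM in this assay, a gap beyond the scatter. Compound 3, `OC1CCN(c2ncnc3[nH]cc(-c4cccc(Cl)c4)c23)CC1`, differs from compound 2 by hydroxy in place of acetamido on a saturated ring carbon. Among the compounds with values here, no measured pair shows this kind of change, so the expectation rests on the limited data. A modest weakening is expected for compound 3, a step of a 2.2-fold higher number from compound 2 to compound 3 (0.33 log units; beyond the scatter). Compound 3 is estimated at 300 nM, within a range from 100 nM to 900 nM.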

Compound 3, half-maximal inhibitory concentration: 433 nM
Compound 3: middle estimate off by 1.4-fold (0.16 log units), on the low side; the range from low to high includes it.
By their numbers in this assay, from the lowest: compound 2; then compounds 3 and 1 (each within the scatter of the next).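

In this assay, hydroxy in place of acetamido on a saturated ring carbon gives a 3.1-fold higher number from compound 2 to compound 3 (0.49 log units; beyond the scatter), so at this position acetamido holds an edge over hydroxy that lies beyond the scatter. On an aromatic carbon, 4-hydroxypiperidin-1-yl in place of (3-hydroxypropyl)amino gives a 1.5-fold lower number from compound 1 to compound 3 (0.19 log units; within the scatter), within the scatter, so these two groups are not told apart here. Nothing at hand bears on the reason for either step. Going by these compounds, whether the edge of acetamido over hydroxy extends to a free amine, a methoxy group or a longer amide chain on this ring carbon remains open.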